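The source may report more compounds than this note shows. Statements on the series, on what has been measured and on what is new or still open speak of the compounds shown alone.

Measured compounds:
- compound 1, `NC(=O)c1ccccc1C(=O)N1CCC(N(C2CC2)S(=O)(=O)c2cccc(C(F)(F)F)c2)CC1`: 15%
- compound 2, `CS(=O)(=O)c1ccc(F)cc1C(=O)N1CCC(N(C2CC2)S(=O)(=O)c2ccc(C(F)(F)F)cc2)CC1`: 1%

In an assay on HEK293 cells for inhibition of Voltage-dependent N-type calcium channel subunit alpha-1B (Homo sapiens), read by FLIPR and calcium flux, tested at 1 uM (a higher number here means more inhibition at the concentration tested (going by the name of the read-out), a lower number less inhibition), compound 1 gives 15%, which is the highest of the two numbers in hand. The nearest is compound 2, which in this assay gives 1%, a lower number, beyond the usual scatter. Among the compounds with values here, compound 2 also differs from compound 1 at the sulfonamide aryl, so no single change can be assigned to that gap; the two values show only that compound 1 inhibits more at the tested concentration.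

Compound 3, `CS(=O)(=O)c1cccc(C(=O)N2CCC(N(C3CC3)S(=O)(=O)c3cccc(C(F)(F)F)c3)CC2)c1`, is not yet measured. It differs from compound 1 by 3-(methylsulfonyl)phenyl in place of 2-carbamoylphenyl on a carbonyl carbon. The group that enters in compound 3 is the same kind of group that compound 2 carries, with the sulfonamide aryl of compound 1 kept. Given that compound 2 gives 1%, a small downward step is expected, though one that may stay within the scatter. The step of a number 7 percentage points lower from compound 1 to compound 3 (within the scatter) is the expected size. Compound 3 is estimated at 8%, in the range 0% to 22%.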

Compound 3, a percentage reported as inhibition, at one concentration (the size of the read-out at that concentration, not a potency): 15%
Compound 3: the middle estimate sits 7 percentage points below what was measured, and the stated range covers the measured number.
By their numbers in this assay, from the lowest: compound 2; then compounds 1 and 3 (each within the scatter of the next).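

At the place on a carbonyl carbon whose other neighbours are: amide-type nitrogen in a ring, 3-(methylsulfonyl)phenyl in place of 2-carbamoylphenyl gives no change at the digits printed from compound 1 to compound 3 (within the scatter) in this assay. The group that leaves carries 1 hydrogen-bond donor and the group that enters carries 0, so in this one pair the amide hydrogen is not required to keep the number, and a methylsulfonyl group on this aryl is compatible with the value of compound 1. No measurement is available that could explain this result.

Compound 2 differs from compound 3 in more than one place, so its lower value remains unassigned, and the role of the sulfonamide aryl at this level of inhibition is still unresolved. Also open, from the compounds shown here alone, is whether the group or its ring position sets the number, which 3-carbamoylphenyl would test, and whether a carboxylic acid or an aminomethyl group on this phenyl would move the value in this assay beyond the scatter.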